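The source may hold more compounds than are shown below. What is called first, only, known or untested is meant among the compounds shown, and "the series" means these compounds.

Compound 3 `COc1ccc(-c2ccc3ncn(-c4cc(OC)c(OC)c(OC)c4)c3c2)cc1F` gives 520 nM in a functional assay on MCF7 cells (Homo sapiens) for antiproliferative activity, read by MTT assay, with a stated time of 72 h (on this read-out lower numbers stand for stronger inhibition and higher numbers for weaker inhibition), the second highest of the three numbers seen so far; compound 1 `COc1ccc(-c2ccc3ncn(-c4cc(OC)c(OC)c(OC)c4)c3c2)cc1` gives 210 nM and compound 2 `COc1cc(-n2cnc3ccc(-c4ccccc4)cc32)cc(OC)c1OC` gives 2290 nM. Compound 4 `COc1cc(-n2cnc3ccc(-c4ccc(O)cc4)cc32)cc(OC)c1OC` differs from compound 3 in one place: 4-hydroxyphenyl in place of 3-fluoro-4-methoxyphenyl on an aromatic carbon. Among the measured compounds shown here, two measured steps bear on this change. Taking the methoxy away altogether gave an 11-fold higher number from compound 1 to compound 2 (1.04 log units; beyond the scatter), whereas adding the fluoro gave a 2.5-fold higher number from compound 1 to compound 3 (0.39 log units; beyond the scatter). Compound 4 drops the fluoro but keeps one hydrogen-bond acceptor in the ring, so the step expected from compound 3 to compound 4, a 1.2-fold lower number from compound 3 to compound 4 (0.06 log units; within the scatter), is small and probably toward a lower number, because an 11-fold higher number from compound 1 to compound 2 (1.04 log units; beyond the scatter) shows that the full loss of the oxygen substituent is what costs most. Compound 4 is therefore estimated at 450 nM, with a range from 130 nM to 1600 nM.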

Compound 4, half-maximal inhibitory concentration: 4160 nM
Beside the measured number, compound 4's estimate is 9.2-fold (0.97 log units) below it; measured number above the stated range.
By their numbers in this assay, from the lowest: compound 1; then compound 3; then compounds 2 and 4 (each within the scatter of the next).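

In this assay, a hydroxy on this ring does not stand in for the methoxy: removing only the methyl from the oxygen gives a 20-fold higher number from compound 1 to compound 4 (1.30 log units; beyond the scatter), and replacing the 3-fluoro-4-methoxyphenyl with 4-hydroxyphenyl gives an 8.0-fold higher number from compound 3 to compound 4 (0.90 log units; beyond the scatter). Adding the hydroxy to the plain phenyl gives a 1.8-fold higher number from compound 2 to compound 4 (0.26 log units; within the scatter), so hydroxy and hydrogen cannot be told apart here. Thus, among these compounds, the methoxy's methyl matters as much as the oxygen.

As far as these compounds go, whether an ethoxy or an amine on this ring would behave like the methoxy or the hydroxy remains open. Nothing measured here gives a reason for these steps.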